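Cinnamamide anilinoquinazolines against prostate cancer cells: halogenated aryl variant

The compounds below may be only part of what the source reports. "The series", "measured", "known", "first", "only" and "open" are said of these compounds alone.

Among the compounds with values here, compound 1 `COc1cc(/C=C/C(=O)Nc2cc3c(Nc4ccc(F)c(Cl)c4)ncnc3cc2O[C@H]2CCOC2)cc(OC)c1OC` is the only member of the series with a numerical result in a functional assay on PC-3 cells (Homo sapiens) for cytotoxicity, read by MTT assay, with a stated time of 72 h (on this read-out lower numbers stand for stronger inhibition and higher numbers for weaker inhibition), where compound 1 gives 20500 nM. Compound 2 `COc1cc(/C=C/C(=O)Nc2cc3c(Nc4ccc(F)c(Cl)c4)ncnc3cc2OC)cc(OC)c1` and compound 3 `COc1cc2ncnc(Nc3ccc(F)c(Cl)c3)c2cc1NC(=O)/C=C/c1ccc(C#N)cc1` were also run in this assay; compound 2 is reported as "not active" (no number reported) and compound 3 as "not active" (no number reported), without a number for either. The series therefore sits at weak inhibition, with compound 1 the sole reference point.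

Compound 4 `O=C(/C=C/c1ccc(F)cc1Cl)Nc1cc2c(Nc3ccc(F)c(Cl)c3)ncnc2cc1O[C@H]1CCOC1` differs from compound 1 only at the aryl end of the unsaturated amide: 2-chloro-4-fluorophenyl in place of 3,4,5-trimethoxyphenyl on a double-bonded chain carbon bound to a double-bonded chain carbon. The groups that leave and enter are both a single six-membered aromatic ring of carbon only, attached at the same double-bonded chain carbon.

Within the data shown here, with no measured pair to calibrate this change, and with compound 3 already inactive in this assay after a different aryl swap, no step beyond the scatter is expected in either direction; a drift toward weaker inhibition or an unnumbered result is plausible. Compound 4 is estimated at 25000 nM in this assay, within 8000 nM to 80000 nM. The expected step of a 1.2-fold higher number from compound 1 to compound 4 (0.09 log units; within the scatter) is thus essentially flat.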

Compound 4, half-maximal inhibitory concentration: 7150 nM
Beside the measured number, compound 4's estimate is 3.5-fold (0.54 log units) above it; the measured number lies below the stated range.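

In this assay, within the data shown here, the aryl group on a double-bonded chain carbon bound to a double-bonded chain carbon proves able to move the result: 2-chloro-4-fluorophenyl in place of 3,4,5-trimethoxyphenyl gives a 2.9-fold lower number from compound 1 to compound 4 (0.46 log units; beyond the scatter) and this is the first step the series can read. The change also shows that the three oxygen atoms of the trimethoxyphenyl group are not required for a numerical result at this position, as compound 4 gives 7150 nM with a ring of carbon and halogens only. Nothing available explains the size or direction of this step.

Going by these compounds, whether the chlorine, the fluorine or the loss of the methoxy groups carries the step remains open. Also open, on these data alone, is how an amine or a carboxylic acid on this aryl ring would read in this assay.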